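Fluoro for Methyl on Two Related Cores

The source may report more compounds than this note shows. Statements on the series, on what has been measured and on what is new or still open speak of the compounds shown alone.

Compound 1 `C/C(=C\c1cc(-c2ccc(C)cc2)co1)C(N)=O` and compound 2 `C/C(=C\c1cc(-c2ccc(F)cc2)co1)C(N)=O` share one core, while compound 3 `C/C(=C\c1ccc(-c2ccc(C)cc2)o1)C(N)=O` and compound 4 `C/C(=C\c1ccc(-c2ccc(F)cc2)o1)C(N)=O` share another built from the same atoms joined differently; the difference between the two cores is not broken down here. In a functional assay on MCF7 cells (Homo sapiens) for cytotoxicity, read by CCK-8 assay, with a stated time of 24 h (on this read-out higher numbers stand for weaker inhibition and lower numbers for stronger inhibition), compound 1 gives 1630 nM. In this assay compound 2 gives 2210 nM. The change fluoro in place of methyl on an aromatic carbon therefore made a 1.4-fold higher number from compound 1 to compound 2 (0.13 log units; within the scatter). For compound 3 this assay reports only a limit, > 50000 nM (the limit of > 50000 nM in this assay, at which 1 of the 3 values shown sits). The same change, (fluoro in place of methyl on an aromatic carbon), leads to compound 4. Given that the earlier step was a 1.4-fold higher number from compound 1 to compound 2 (0.13 log units; within the scatter), compound 4 is expected to remain at that limit as well. The step expected is a step that the limit leaves unreadable from compound 3 to compound 4. Compound 4 is estimated at 60000 nM, plausibly between 20000 nM and 200000 nM.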

Compound 4, half-maximal inhibitory concentration: 970 nM
Compound 4: the middle estimate sits 62-fold (1.79 log units) above what was measured, and the stated range ends above it.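

In this assay, the result of putting fluoro in place of methyl did not carry over from one core to the other, with an at least 51-fold lower number from compound 3 to compound 4 (1.71 log units; beyond the scatter) set against the earlier step: the same change on two cores in this assay, a 1.4-fold higher number (0.13 log units; within the scatter) from compound 1 to compound 2 and an at least 51-fold lower number (1.71 log units; beyond the scatter) from compound 3 to compound 4, at least 69-fold (1.84 log units) apart, beyond the scatter of two such steps. The new step is only a minimum, and compound 3 has no exact number: the limit of > 50000 nM in this assay, at which 1 of the 4 values shown sits. These two pairs show that the outcome of this change depends on the core, but they give no rule for other cores and do not show which feature of the cores produces the difference.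

As far as these compounds go, it remains open whether chloro, an amine or a carboxylic acid in place of the methyl would also separate the two cores. From the compounds shown here alone, the true value of compound 3 also remains unknown.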